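Notes on the Urea Series: Acetyl for Isopropyl

The source may report more compounds than this note shows. Statements on the series, on what has been measured and on what is new or still open speak of the compounds shown alone.

Compound 2 `CC(C)c1cccc(NC(=O)N[C@@H](C)c2ccccc2)c1` stands second highest of the three numbers in an ADME assay on the whole organism with Oryza sativa as the target, tested at 1 uM (on this read-out higher numbers stand for a weaker effect at the one concentration tested and lower numbers for a stronger effect), where compound 2 gives 84%. Compound 1 `CC(C)c1cccc(NC(=O)N[C@H](C)c2ccccc2)c1` gives 61%, and compound 3 `CCCCCc1ccc(NC(=O)N[C@H](C)c2ccccc2)cc1` gives 101%. Within the data shown here, the only single-place step measured so far, a number 23 percentage points higher from compound 1 to compound 2 (beyond the scatter), turns on the fact that compounds 1 and 2 differ only in the configuration as drawn and concerns the stereocentre, not the group on the aromatic ring. Compound 4 `CC(=O)c1cccc(NC(=O)N[C@@H](C)c2ccccc2)c1` differs from compound 2 by acetyl in place of isopropyl on an aromatic carbon. Among the measured compounds shown here, no measured step bears on this change, so there is no basis for expecting a step beyond the scatter in either direction. Compound 4 is therefore estimated at 84%, within 62% to 104%. The implied step no change at the digits printed from compound 2 to compound 4 (within the scatter) is expected to stay within the scatter.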

Compound 4, a percentage reported as activity, at one concentration (the size of the read-out at that concentration, not a potency): 95%
Beside the measured number, compound 4's estimate is 11 percentage points below it, and the stated range covers the measured number.
By their numbers in this assay, from the lowest: compound 1; then compound 2; then compounds 4 and 3 (each within the scatter of the next).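

In this assay, acetyl in place of isopropyl on an aromatic carbon gives a number 11 percentage points higher from compound 2 to compound 4 (beyond the scatter), so the group at this position moves the read-out, as the stereocentre does, and the higher number stands for a weaker effect. The two groups match in heavy atoms, while acetyl adds 1 hydrogen-bond acceptor. Nothing available accounts for this step.

On these data alone, whether an amine, a carboxylic acid or a longer chain at this position would shift the number in either direction remains open. So does the size of the same change in the configuration drawn in compound 1.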